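Swapping the aniline aryl group on a shared core

A few compounds are considered here, and "the series" means these few. Any claim that something is new, unique, unknown or untested is made for them only; others in the source may bear on it.

Compound 1 `COc1ccc(Nc2ncc(C(F)(F)F)c(N3Cc4cccc(N(C)S(C)(=O)=O)c4C3)n2)cc1C(F)(F)F`: in a functional assay on OVCAR-3 cells (Homo sapiens) for antiproliferative activity, read by spectrophotometry, with a stated time of 2 days (on this read-out lower numbers stand for stronger inhibition of growth and higher numbers for weaker inhibition of growth), compound 1 gives > 30000 nM, which is a limit of the assay and not a number.
Compound 2 `CN(c1cccc2c1CN(c1nc(Nc3cc(C(F)(F)F)cc(C(F)(F)F)c3)ncc1C(F)(F)F)C2)S(C)(=O)=O`: in this assay compound 2 gives > 30000 nM, again a limit.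
Compound 3 `Cc1cc(Cl)ccc1Nc1ncc(C(F)(F)F)c(N2Cc3cccc(N(C)S(C)(=O)=O)c3C2)n1`: in this assay compound 3 gives > 30000 nM, also a limit.

Compound 3 therefore stands at the same limit as the other two measured compounds, and the limit of > 30000 nM in this assay, at which 3 of the 3 values shown sit, shows that every value recorded so far sits there. Within the data shown here, the one measured step that touches compound 3, a step that the two limits leave unreadable from compound 1 to compound 3, cannot be read in size or direction, since both ends are limits.

Compound 4 `CN(c1cccc2c1CN(c1nc(Nc3ccc(C(F)(F)F)cc3)ncc1C(F)(F)F)C2)S(C)(=O)=O` differs from compound 3 by 4-(trifluoromethyl)phenyl in place of 4-chloro-2-methylphenyl on a nitrogen on an aromatic ring. Among the measured compounds shown here, no measured step bears on this change, and the only comparable step, the one from compound 1 to compound 3, is unreadable. Compound 4 is expected to remain at the limit, because the limit of > 30000 nM in this assay, at which 3 of the 3 values shown sit, holds every value shown; the step of a number no higher from compound 3 to compound 4 (the limit leaves the size open) is expected to be none beyond the scatter. The estimate for compound 4 is 30000 nM, expected between 10000 nM and 100000 nM.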

Compound 4, concentration for 50% growth inhibition: > 30000 nM
Compound 4 gave a limit, no number; the forecaster's own chance of this, stated with the estimate: 85%; the middle value sits exactly at the limit.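

Compound 4 also gives a limit and not a number, so the steps to it from compound 1 and from compound 3 cannot be read in size or direction. The compounds shown leave open how these aryl groups rank against one another, since all share a single result: the limit of > 30000 nM in this assay, at which 4 of the 4 values shown sit.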